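Swapping the ring on the piperazine arm: imidazole to pyrazole

This account rests on a few compounds, and the source may have more. Where it says the series, first, only, none or still open, it means among the compounds named here.

The measured compounds so far:
- Compound 1 `Cc1ccc(CN2CCN(c3cccc4[nH]c(-c5ccc(C(C)(C)C)cc5)nc34)CC2)o1`: 705 nM
- Compound 2 `Cn1cnc(CN2CCN(c3cccc4[nH]c(-c5ccc(C(C)(C)C)cc5)nc34)CC2)c1`: 33 nM
- Compound 3 `Cc1nc(CN2CCN(c3cccc4[nH]c(-c5ccc(C(C)(C)C)cc5)nc34)CC2)c(C)s1`: 21 nM

All three share the same core and differ only in the small aromatic ring attached to a saturated chain carbon bound to an amine nitrogen in a ring. In an assay on isolated protein for displacement of a labelled ligand from Gonadotropin-releasing hormone receptor (Homo sapiens) (a higher number here means a weaker inhibitor, a lower number a stronger inhibitor), compound 2 gives 33 nM, the second highest of the three numbers. Its nearest neighbour is compound 3, with a 1.6-fold lower number from compound 2 to compound 3 (0.20 log units; within the scatter), a gap within the usual scatter, so the two cannot be told apart. Its furthest neighbour is compound 1, at a 21-fold lower number from compound 1 to compound 2 (1.33 log units; beyond the scatter).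

The next compound, compound 4 `Cc1cc(CN2CCN(c3cccc4[nH]c(-c5ccc(C(C)(C)C)cc5)nc34)CC2)nn1C`, carries the change (1,5-dimethyl-1H-pyrazol-3-yl in place of 1-methyl-1H-imidazol-4-yl on a saturated chain carbon bound to an amine nitrogen in a ring).

Two steps speak to this. Replacing 5-methylfuran-2-yl by one five-membered aromatic ring with 2 hetero atoms gave large gains, a 21-fold lower number from compound 1 to compound 2 (1.33 log units; beyond the scatter) and a 34-fold lower number from compound 1 to compound 3 (1.53 log units; beyond the scatter). Moving between two such rings gave only a 1.6-fold lower number from compound 2 to compound 3 (0.20 log units; within the scatter), within the scatter. The new 1,5-dimethyl-1H-pyrazol-3-yl is again one five-membered aromatic ring with 2 hetero atoms, 2 hydrogen-bond acceptors, so no step beyond the scatter is expected in this assay, in either direction.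

Compound 4 is therefore estimated at 30 nM, within a range from 10 nM to 100 nM, an expected 1.1-fold lower number from compound 2 to compound 4 (0.04 log units; within the scatter).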

Compound 4, half-maximal inhibitory concentration: 83 nM
The estimate for compound 4 lay 2.8-fold (0.44 log units) below the measured number; low and high end bracket the measured number.
By their numbers in this assay, from the lowest: compounds 3 and 2 (each within the scatter of the next); then compound 4; then compound 1.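

In this assay, this place on a saturated chain carbon bound to an amine nitrogen in a ring separates rings that look alike when counted: 1,5-dimethyl-1H-pyrazol-3-yl and 1-methyl-1H-imidazol-4-yl are both five-membered aromatic rings with 2 hetero atoms and 2 hydrogen-bond acceptors, yet this change gives a 2.5-fold higher number from compound 2 to compound 4 (0.40 log units; beyond the scatter), and putting the same pyrazole in place of 2,5-dimethyl-1,3-thiazol-4-yl gives a 4.0-fold higher number from compound 3 to compound 4 (0.60 log units; beyond the scatter). The advantage over 5-methylfuran-2-yl remains, with an 8.5-fold lower number from compound 1 to compound 4 (0.93 log units; beyond the scatter), so all three rings with 2 hetero atoms give lower numbers than the furan ring, but they do not all reach the same level. No other measurement is available to explain the difference among these rings.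

The compounds shown do not separate the extra methyl of compound 4 from the different arrangement of its ring nitrogens, a question that 1-methyl-1H-pyrazol-3-yl, with one methyl only, would help to answer. Also open, as far as these compounds go, is how this assay responds to an amine or a carboxylic acid on the ring, or to a longer chain leading to it.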